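The compounds below may be only part of what the source reports. "The series", "measured", "known", "first", "only" and "open" are said of these compounds alone.

Working notes on the series: compound 1 `COc1cc(NC(C)CCCNC(=O)NNC(=O)NCCO)c2ncccc2c1`, compound 2 `COc1cc(NC(C)CCCNC(=O)NNC(=O)NC(CO)(CO)CO)c2ncccc2c1` and the unmeasured compound 3 `COc1cc(NC(C)CCCNC(=O)NNC(=O)N(CCO)CCO)c2ncccc2c1` share the core of compound 1 and differ in one place. In a functional assay on SW-620 cells (Homo sapiens) for inhibition, read by MTT assay, with a stated time of 4 days (on this read-out higher numbers stand for weaker inhibition and lower numbers for stronger inhibition), compound 2 gives > 100000 nM, which is a limit and not a number. In this assay compound 1 gives > 100000 nM, also a limit. Compound 2 therefore has no numeric standing in the series, and the evidence so far is the limit of > 100000 nM in this assay, at which 2 of the 2 values shown sit.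

The change to compound 3 is bis(2-hydroxyethyl)amino in place of (2-hydroxy-1,1-bis(hydroxymethyl)ethyl)amino on a carbonyl carbon.

Going by the values given here, the only measured step that bears on this is a step that the two limits leave unreadable from compound 1 to compound 2. It has no readable size, so it offers neither a magnitude nor a direction to carry over. No step beyond the scatter is therefore expected in this assay, and a further limit is the likeliest report. The expected step is a number no higher from compound 2 to compound 3 (the limit leaves the size open). For compound 3 the estimate is 100000 nM, with an expected range of 40000 nM to 150000 nM.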

Compound 3, half-maximal inhibitory concentration: > 100000 nM
Compound 3: a limit, no number; the forecaster's own chance of this, stated with the estimate: 75%; the middle value lies on the limit itself.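

Compound 3 also returns a limit and not a number in this assay, so no step among compound 1, compound 2 and compound 3 can be read, and the evidence remains: the limit of > 100000 nM in this assay, at which 3 of the 3 values shown sit.

The compounds shown leave open whether any of these three compounds has a measurable value in this read-out, and how large any difference among them would be.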